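Isopropyl for chloro on the fused benzene ring

The compounds below may be only part of what the source reports. "The series", "measured", "known", "first", "only" and "open" are said of these compounds alone.

Compound 1 `CNc1nc2ccccc2c(=O)o1` gives only a limit of the assay, > 62500 nM, in an assay on isolated protein for inhibition of complement C1r subcomponent (Homo sapiens); on this read-out lower numbers stand for stronger inhibition and higher numbers for weaker inhibition. Compound 2 `O=c1oc(Nc2ccccc2I)nc2cc(Cl)ccc12` gives 700 nM in this assay, and compound 3 `O=c1oc(Nc2ccccc2I)nc2cc(Cl)c(Cl)cc12` gives 500 nM. Compound 2 thus carries the higher of the two numbers recorded, with compound 3 nearest; the step of a 1.4-fold lower number from compound 2 to compound 3 (0.15 log units; within the scatter) shows how close they lie. Compound 4 `CC(C)c1ccc2c(=O)oc(Nc3ccccc3I)nc2c1` differs from compound 2 by isopropyl in place of chloro on an aromatic carbon. Going by the values given here, the only measured step at that ring, adding chloro, stayed within the scatter, and no step exchanges chloro for an alkyl group, so for compound 4 a change no larger than the scatter is expected in this assay, with a 1.1-fold higher number from compound 2 to compound 4 (0.06 log units; within the scatter) as the expected shift. Compound 4 is therefore estimated at 800 nM, between 250 nM and 2500 nM.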

Compound 4, half-maximal inhibitory concentration: > 62500 nM
Compound 4: only a limit was reported (the forecaster's own chance of this, stated with the estimate: 5%); at least 78-fold (1.89 log units) between middle value and limit.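

In this assay, this aromatic carbon does not accept every exchange: chloro to isopropyl gives a large step (an at least 89-fold higher number from compound 2 to compound 4 (1.95 log units; beyond the scatter)), whereas the earlier step on this ring, adding chloro, stayed within the scatter (a 1.4-fold lower number from compound 2 to compound 3 (0.15 log units; within the scatter)). Compound 4 gives only a limit of the assay, the same limit as compound 1: the limit of > 62500 nM in this assay, at which 2 of the 4 values shown sit.

The compounds shown leave open whether methyl, ethyl or methoxy at this carbon would keep the value of compound 2. They also leave open how an amine or a carboxylic acid would fare there.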